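The compounds below may be only part of what the source reports. "The series", "measured", "known", "first", "only" and "open" are said of these compounds alone.

Compound 1, `CCCCn1c(=O)[nH]c2nc(-c3cnn(Cc4cccc(C(F)(F)F)c4)c3)[nH]c2c1=O`: > 6000 nM
Compound 2, `CC(C)Cn1c(=O)[nH]c2nc(-c3cnn(Cc4cccc(F)c4)c3)[nH]c2c1=O`: > 6000 nM

In an assay on CHO cells for displacement of a labelled ligand from adenosine receptor A1 (Homo sapiens) (on this read-out higher numbers stand for weaker inhibition and lower numbers for stronger inhibition), compound 1 gives only a limit of the assay, not a number. Compound 2 likewise gives only a limit in this assay. Compound 2 therefore stands where both measured values stand, at the limit of > 6000 nM in this assay, at which 2 of the 2 values shown sit, and nothing in the numbers sets it apart from compound 1.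

Compound 3, `CC(C)Cn1c(=O)[nH]c2nc(-c3cnn(Cc4cccc(C(F)(F)F)c4)c3)[nH]c2c1=O`, has not yet been measured. For the measured compounds named here, it differs from compound 2 by trifluoromethyl in place of fluoro on an aromatic carbon; the group it takes on is the one that compound 1 already carries. Going by the values given here, no step between measured compounds is available, and both measured compounds sit at the same limit, so no shift beyond the usual scatter is expected from compound 2 to compound 3 in this assay. The step from compound 2 to compound 3 is expected to be a step that the limit leaves unreadable from compound 2 to compound 3. Compound 3 is accordingly estimated at 10000 nM, in a range from 4000 nM to 30000 nM, most likely again reported only as a limit.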

Compound 3, inhibition constant: > 6000 nM
Compound 3 gave a limit, no number (the forecaster's own chance of this, stated with the estimate: 85%); the middle value is on the limit's open side.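

Compound 3 also gives only a limit in this assay, so neither the step from compound 2 nor the step from compound 1 to compound 3 can be read: the limit of > 6000 nM in this assay, at which 3 of the 3 values shown sit.

The compounds shown leave open how strongly each inhibits in this assay, and whether either single change shifts that inhibition at all.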